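The Same Exchange Tried on a Second Core

This account rests on a few compounds, and the source may have more. Where it says the series, first, only, none or still open, it means among the compounds named here.

The measured compounds were all tested in an ADME assay on HEK-293T cells (Homo sapiens) for cytotoxicity, read by CCK-8 assay, with a stated time of 48 h; on this read-out lower numbers stand for stronger inhibition and higher numbers for weaker inhibition. Compound 1 `O=[N+]([O-])c1cccc(NC(=S)NCCNS(=O)(=O)c2ccc(-c3ccccc3OCc3ccccc3)s2)c1` gives 18300 nM. Compound 2 `Cc1cc(C)cc(NC(=O)NCCNS(=O)(=O)c2ccc(-c3ccccc3OCc3ccccc3)s2)c1` gives > 20000 nM, which is a limit of the assay rather than a number. Compound 3 `O=[N+]([O-])c1cccc(NC(=S)NCCNS(=O)(=O)c2ccc(-c3ccccc3OCc3cccc(O)c3)s2)c1` gives 13800 nM.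

Compound 1 and compound 3 share a core that differs in one spot: hydroxy in place of hydrogen on an aromatic carbon. On this assay that change amounts to a 1.3-fold lower number from compound 1 to compound 3 (0.12 log units; within the scatter), so the two cores cannot be told apart here.

Compound 2 arises from compound 1 by a second kind of change, (a group of 11 heavy atoms (9 carbon, 1 nitrogen, 1 oxygen; one six-membered aromatic ring of carbon only) in place of a group of 12 heavy atoms (7 carbon, 2 nitrogen, 2 oxygen, 1 sulfur; one six-membered aromatic ring of carbon only), on an amine nitrogen). The step it made, an at least 1.0-fold higher number from compound 1 to compound 2 (0.03 log units; that floor lies within the scatter), is tied to the limit of > 20000 nM in this assay, at which 1 of the 3 values shown sits, so only a floor for it is known.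

Compound 4 `Cc1cc(C)cc(NC(=O)NCCNS(=O)(=O)c2ccc(-c3ccccc3OCc3cccc(O)c3)s2)c1`, not yet measured, is built by applying the same change to compound 3: a group of 11 heavy atoms (9 carbon, 1 nitrogen, 1 oxygen; one six-membered aromatic ring of carbon only) in place of a group of 12 heavy atoms (7 carbon, 2 nitrogen, 2 oxygen, 1 sulfur; one six-membered aromatic ring of carbon only), on an amine nitrogen. The place lines of the two changes read the same word for word, so this is the same change on a core that differs only by the hydroxy described above.

Compound 4 is therefore expected to give about 22000 nM, with a range from 12000 nM to 45000 nM. The expected step of a 1.6-fold higher number from compound 3 to compound 4 (0.20 log units; within the scatter) is estimated to resemble the earlier one because an at least 1.0-fold higher number from compound 1 to compound 2 (0.03 log units; that floor lies within the scatter) ran into the limit, and a limit rather than a number is the most likely outcome for compound 4 as well.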

Compound 4, half-maximal inhibitory concentration: > 20000 nM
Compound 4: no number, only a limit (the forecaster's own chance of this, stated with the estimate: 65%); the middle value does not contradict the limit.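

In this assay compound 4 gives > 20000 nM, which is a limit and not a number. Carried to the core of compound 3, the change to (3,5-dimethylphenyl)carbamoyl on the amine nitrogen can therefore be stated only as an at least 1.4-fold higher number from compound 3 to compound 4 (0.16 log units; that floor lies within the scatter), and what the two cores share is that the change ends at a limit on both: the limit of > 20000 nM in this assay, at which 2 of the 4 values shown sit. This agreement does not show that the change has the same size on each core, and the step from compound 2 to compound 4, which carries the hydroxy exchange, cannot be read at all: the same change on two cores in this assay, an at least 1.0-fold higher number (0.03 log units; that floor lies within the scatter) from compound 1 to compound 2 and an at least 1.4-fold higher number (0.16 log units; that floor lies within the scatter) from compound 3 to compound 4; the limit leaves it open whether they differ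

The exchange replaces a whole group in one move, so the compounds shown leave open which part of that group goes with the readings in this assay. They also leave open how the same exchange would read on a core carrying an amine or a carboxylic acid in place of the hydroxy, or a longer chain in place of the saturated chain on the amine nitrogen.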